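The source may hold more compounds than are shown below. What is called first, only, known or untested is meant among the compounds shown, and "the series" means these compounds.

Measured compounds in the series:
- compound 1 `Fc1ccc(CN2CCC(NCCSC(c3ccc(F)cc3)c3ccc(F)cc3)CC2)cc1`: 25.5 nM
- compound 2 `Fc1ccc(C(SCCNC2CCN(Cc3ccc(Cl)cc3)CC2)c2ccc(F)cc2)cc1`: 39.6 nM
- compound 3 `O=C(c1cc2ccccc2[nH]1)N1CCC(NCCSC(c2ccc(F)cc2)c2ccc(F)cc2)CC1`: 177 nM

All three share the same core and were tested in an assay on membranes from striatum (strain Sprague-Dawley) for displacement of a labelled ligand from sodium-dependent dopamine transporter (Rattus norvegicus), read by scintillation counting, with a stated time of 120 min; on this read-out higher numbers stand for weaker inhibition and lower numbers for stronger inhibition. Compound 3 stands at the highest number of the three; its nearest neighbour is compound 2, and the gap is described by a 4.5-fold higher number from compound 2 to compound 3 (0.65 log units; beyond the scatter). The gap to compound 1 is given by a 6.9-fold higher number from compound 1 to compound 3 (0.84 log units; beyond the scatter). The pair of benzyl analogues sits close together: a 1.6-fold higher number from compound 1 to compound 2 (0.19 log units; within the scatter).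

The next compound, compound 4 `Fc1ccc(C(SCCNC2CCN(CC3CC3)CC2)c2ccc(F)cc2)cc1`, is not yet measured. It differs from compound 3 in one place: cyclopropylmethyl in place of (1H-indol-2-yl)carbonyl on an amine nitrogen in a ring. The two measured steps that bear on this change are the ones in which the (1H-indol-2-yl)carbonyl group entered in place of a benzyl group, a 6.9-fold higher number from compound 1 to compound 3 (0.84 log units; beyond the scatter) and a 4.5-fold higher number from compound 2 to compound 3 (0.65 log units; beyond the scatter). Both went to higher numbers by a modest margin. Within the data shown here, removing the (1H-indol-2-yl)carbonyl group again should therefore reverse that direction, although no measured step covers a cyclopropylmethyl group on the ring nitrogen, so the size is uncertain. For compound 4 a lower number in this assay is expected, with a step of about a 4.4-fold lower number from compound 3 to compound 4 (0.65 log units; beyond the scatter). Compound 4 is estimated at 40 nM, in the range 15 nM to 120 nM.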

Compound 4, inhibition constant: 407 nM
The estimate for compound 4 lay 10-fold (1.01 log units) below the measured number; measured number outside the range, above it.
By their numbers in this assay, from the lowest: compounds 1 and 2 (each within the scatter of the next); then compound 3; then compound 4.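

Removing the (1H-indol-2-yl)carbonyl group from the amine nitrogen in the ring does not by itself lower the number in this assay: with cyclopropylmethyl in its place there is a 2.3-fold higher number from compound 3 to compound 4 (0.36 log units; beyond the scatter), so the higher number of compound 3 cannot be put down simply to the presence of that group. Among these compounds, the larger gaps lie with the benzyl analogues, a 10-fold higher number from compound 2 to compound 4 (1.01 log units; beyond the scatter) and a 16-fold higher number from compound 1 to compound 4 (1.20 log units; beyond the scatter), which makes the halogenated benzyl groups, and not just any small group on this nitrogen, the substituents linked to the lowest numbers among the four compounds, with no compound going against that order. No measurement at hand accounts for this order.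

Cyclopropylmethyl differs from the other three substituents both in lacking an aromatic ring and in its count of 4 heavy atoms, so the compounds shown do not tell which of these differences goes with the higher number. An unsubstituted benzyl, a 2-phenylethyl group or a straight butyl chain on the same nitrogen would help separate the two, and a (1H-indol-2-yl)methyl group would test the carbonyl on its own.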